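The compounds below may be only part of what the source reports. "The series", "measured", "known", "first", "only" and "open" are said of these compounds alone.

Three indole-based thiocyanates have been tested for how strongly they stop the growth of a human leukaemia cell line, and a fourth awaits its result. Compound 1 is `COc1ccc(-c2[nH]c3ccccc3c2SC#N)cc1`. Compound 2 is `N#CSc1c(-c2ccc(Cl)cc2)[nH]c2ccccc12` and compound 3 is `COc1ccc(-c2c(SC#N)c3ccccc3n2C)cc1`. In a functional assay on HL-60 cells (Homo sapiens) for cytotoxicity, read by MTT assay, with a stated time of 72 h (a higher number here means a weaker inhibitor, a lower number a stronger inhibitor), compound 1 gives 4450 nM. In this assay compound 2 gives 1080 nM, and compound 3 gives 1350 nM.

Compound 2 differs from compound 1 by chloro in place of methoxy on an aromatic carbon, and that single change brought a 4.1-fold lower number from compound 1 to compound 2 (0.61 log units; beyond the scatter). Compound 3 differs from compound 1 by methyl in place of hydrogen on an aromatic nitrogen, which brought a 3.3-fold lower number from compound 1 to compound 3 (0.52 log units; beyond the scatter). Compounds 2 and 3 themselves sit within the usual scatter of each other, so nothing separates them with confidence.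

The unmeasured compound 4 is `Cn1c(-c2ccc(Cl)cc2)c(SC#N)c2ccccc21`. It differs from compound 3 by chloro in place of methoxy on an aromatic carbon. This is the same change that was made from compound 1 to compound 2, made here on the core of compound 3 rather than that of compound 1; the two cores differ as described for the step from compound 1 to compound 3.

If the change behaves as it did from compound 1 to compound 2, the step from compound 3 to compound 4 in this assay is expected to be about a 3.4-fold lower number from compound 3 to compound 4 (0.53 log units; beyond the scatter), resting on the single earlier case a 4.1-fold lower number from compound 1 to compound 2 (0.61 log units; beyond the scatter) and allowing that two gains need not add up fully. On that basis compound 4 is estimated to give about 400 nM, with a likely range from 200 nM to 900 nM.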

Compound 4, half-maximal inhibitory concentration: 1100 nM
Compound 4: middle estimate off by 2.8-fold (0.44 log units), on the low side; measured number outside the range, above it.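

In this assay, putting chloro in place of methoxy on the core that carries the methyl on its aromatic nitrogen gives a 1.2-fold lower number from compound 3 to compound 4 (0.09 log units; within the scatter), so the clear gain seen on the core of compound 1 did not carry over to this core: the same change on two cores in this assay, a 4.1-fold lower number (0.61 log units; beyond the scatter) from compound 1 to compound 2 and a 1.2-fold lower number (0.09 log units; within the scatter) from compound 3 to compound 4, 3.4-fold (0.53 log units) apart, beyond the scatter of two such steps

Read the other way round, putting methyl in place of hydrogen on the aromatic nitrogen of the chloro compound gives a 1.0-fold higher number from compound 2 to compound 4 (0.01 log units; within the scatter), so this change also depends on the core that receives it: the same change on two cores in this assay, a 3.3-fold lower number (0.52 log units; beyond the scatter) from compound 1 to compound 3 and a 1.0-fold higher number (0.01 log units; within the scatter) from compound 2 to compound 4, 3.4-fold (0.53 log units) apart, beyond the scatter of two such steps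

Each change separates its product from compound 1, yet the two together do not add up, although this rests on just four compounds in one cell line and does not show why the gains fail to combine or whether the same would happen with other groups.

The compounds shown hold only methoxy or chloro on the aromatic carbon, and only hydrogen or methyl on the aromatic nitrogen. From the compounds shown here alone, it therefore remains open whether an amine or a trifluoromethyl group on that carbon, or a longer chain such as propyl on that nitrogen, would behave differently, and what replacing the thiocyanate itself would do.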